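The source may hold more compounds than are shown below. What is called first, only, known or untested is meant among the compounds shown, and "the series" means these compounds.

Working notes on the series. All three measured compounds keep one core and vary a single group on an aromatic carbon, para to a large group. Compound 1 `CC(C)Oc1ccc(CNC(=O)c2ccc(C(C)(C)C)cc2)cc1` carries isopropoxy, compound 2 `CC(C)(C)c1ccc(C(=O)NCc2ccc(NS(C)(=O)=O)cc2)cc1` methanesulfonamido, compound 3 `CN(C)C(=O)c1ccc(CNC(=O)c2ccc(C(C)(C)C)cc2)cc1` dimethylcarbamoyl. In an assay on HeLa cells with Bile acid receptor (Homo sapiens) as the target, read by a luciferase reporter, with a stated time of 24 h (on this read-out higher numbers stand for an effect only at larger amounts of compound and lower numbers for an effect already at smaller amounts), compound 1 gives 170 nM. Compound 2 gives 44 nM in this assay. Compound 3 gives 170 nM in this assay. The steps read a 3.9-fold lower number from compound 1 to compound 2 (0.59 log units; beyond the scatter), no change at the digits printed from compound 1 to compound 3 (within the scatter) and a 3.9-fold higher number from compound 2 to compound 3 (0.59 log units; beyond the scatter). Compound 3 thus stands level with compound 1, the two together holding the highest of the three numbers, with only compound 2 lower.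

Compound 4 `CC(C)(C)c1ccc(C(=O)NCc2ccc(OC(F)(F)F)cc2)cc1` awaits measurement. The change from compound 3 is trifluoromethoxy in place of dimethylcarbamoyl on an aromatic carbon. Going by the values given here, two measured steps bear on this carbon: replacing isopropoxy by dimethylcarbamoyl left the number unchanged, while the methanesulfonamido case moved it modestly. Among the compounds with values here, no measured compound carries trifluoromethoxy, so the expectation rests on the unchanged step from compound 1 to compound 3. The expected change for compound 4 is a step of about no change at the digits printed from compound 3 to compound 4 (within the scatter), that is, nothing beyond the scatter. Compound 4 is therefore expected near 170 nM in this assay, within 60 nM to 450 nM.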

Compound 4, half-maximal effective concentration: 160 nM
For compound 4 the middle estimate is 1.1-fold (0.03 log units) above the measured one, within the range that was stated.
By their numbers in this assay, from the lowest: compound 2; then compounds 4, 1 and 3 (each within the scatter of the next).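

In this assay trifluoromethoxy joins isopropoxy and dimethylcarbamoyl as a third group on this aromatic carbon that sits at one level: the exchange for dimethylcarbamoyl reads a 1.1-fold lower number from compound 3 to compound 4 (0.03 log units; within the scatter) and trifluoromethyl in place of isopropyl on the oxygen reads a 1.1-fold lower number from compound 1 to compound 4 (0.03 log units; within the scatter) as well. Methanesulfonamido stays apart, with a 3.6-fold higher number from compound 2 to compound 4 (0.56 log units; beyond the scatter) on exchange for trifluoromethoxy, so among the four compounds only compound 2 departs from that level. Nothing measured on these groups accounts for this result.

The compounds shown leave open whether the lower number of compound 2 belongs to methanesulfonamido alone. A methylsulfonyl group joined directly to the ring, a carboxylic acid or a primary amine on this carbon would bear on that question.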